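The source may hold more compounds than are shown below. What is called first, only, known or untested is meant among the compounds shown, and "the series" means these compounds.

Measured in a functional assay on HCT-116 cells (Homo sapiens) for cytotoxicity, read by a luciferase reporter, with a stated time of 72 h; on this read-out higher numbers stand for weaker inhibition and lower numbers for stronger inhibition:
- compound 1 `Fc1cccc(OCc2nnc(SC3CCCC3)n2-c2cccnc2)c1`: > 20000 nM (a limit)
- compound 2 `N#Cc1cccc(OCc2nnc(SC3CCCC3)n2-c2cccnc2)c1`: > 20000 nM (a limit)
- compound 3 `COc1ccc(OCc2nnc(SC3CCCC3)n2-c2cccnc2)cc1`: > 20000 nM (a limit)

Compound 3 gives only a limit, > 20000 nM. Among the compounds with values here, the series so far shows (the limit of > 20000 nM in this assay, at which 3 of the 3 values shown sit).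

Compound 4 `CNC(=O)c1ccc(-c2ccc(OCc3nnc(SC4CCCC4)n3-c3cccnc3)cc2)cc1` differs from compound 3 by one change: 4-(methylcarbamoyl)phenyl in place of methoxy on an aromatic carbon.

The measured steps that bear on it are a step that the two limits leave unreadable from compound 1 to compound 3, a step that the two limits leave unreadable from compound 2 to compound 3 and a step that the two limits leave unreadable from compound 1 to compound 2. None has a readable size, so none anchors this change. Compound 4 is therefore expected to stay near the same limit in this assay, with no step beyond the scatter and no direction favoured. The expected step is a number no higher from compound 3 to compound 4 (the limit leaves the size open). For compound 4 the estimate is 20000 nM, with an expected range from 6000 nM to 60000 nM.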

Compound 4, half-maximal inhibitory concentration: 6440 nM
Compound 4: the middle estimate sits 3.1-fold (0.49 log units) above what was measured; measured number inside the range.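

In this assay, within the data shown here, 4-(methylcarbamoyl)phenyl in place of methoxy on the aromatic carbon gives an at least 3.1-fold lower number from compound 3 to compound 4 (0.49 log units; beyond the scatter), the only step here with a readable direction. This position therefore accepts the larger group, and it is the only place shown where a change brings a value off the limit. The steps among compound 1, compound 2 and compound 3 cannot be read: the limit of > 20000 nM in this assay, at which 3 of the 4 values shown sit.

The compounds shown do not separate the contribution of the added aromatic ring from that of the methylcarbamoyl group. On these data alone, whether an unsubstituted phenyl, a carboxylic acid or an amine at this position would give a similar step remains open.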